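Removing the ester arm from a cyanochromanol aniline

The compounds below may be only part of what the source reports. "The series", "measured", "known", "first", "only" and "open" are said of these compounds alone.

compound 1, `CCOC(=O)CN(c1ccccc1)[C@H]1c2cc(C#N)ccc2OC(C)(C)[C@@H]1O`: > 30000 nM in a functional assay (aorta) with Rattus norvegicus as the target (a lower number here means a stronger inhibitor, a higher number a weaker inhibitor), a limit of the assay
compound 2, `CCOC(=O)CN(c1ccccc1)[C@@H]1c2cc(C#N)ccc2OC(C)(C)[C@H]1O`: > 30000 nM in this assay, a limit of the assay

Compound 1 stands at the ceiling of this assay, with no number of its own, and the same holds for every value shown (the limit of > 30000 nM in this assay, at which 2 of the 2 values shown sit). Compound 2 is its mirror image (the fact that compounds 1 and 2 differ only in the configuration as drawn), and the step that the two limits leave unreadable from compound 1 to compound 2 cannot be read because both ends sit at the limit (the limit of > 30000 nM in this assay, at which 2 of the 2 values shown sit). Compound 3 `CC1(C)Oc2ccc(C#N)cc2[C@H](Nc2ccccc2)[C@H]1O` differs from compound 1 by hydrogen in place of (ethoxycarbonyl)methyl on a nitrogen on an aromatic ring. Going by the values given here, no measured step bears on this change; the only step measured, between the two mirror images, is unreadable in size, so it offers no guide in either direction. For compound 3 the expected step from its parent is an at least 2.0-fold lower number from compound 1 to compound 3 (0.30 log units; that floor lies within the scatter), an estimate resting on nothing more than the limit of compound 1. Compound 3 is therefore estimated at 15000 nM, between 1500 nM and 60000 nM, with a real chance that only a limit is reported again.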

Compound 3, half-maximal inhibitory concentration: 1200 nM
Compound 3: the middle estimate sits 13-fold (1.10 log units) above what was measured; the whole stated range lies above it.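

Going by these compounds alone, putting hydrogen in place of (ethoxycarbonyl)methyl on the nitrogen on an aromatic ring gives the only readable value shown in this assay, with an at least 25-fold lower number from compound 1 to compound 3 (1.39 log units; beyond the scatter). Compound 3 alone comes off the ceiling, so substitution on this nitrogen affects the read-out strongly, something the pair of mirror images, compound 1 and compound 2, could not show, as the step between them cannot be read. On these data alone, the true size of the new step remains unknown and the printed figure is only a floor, because compound 1 has no number of its own: the limit of > 30000 nM in this assay, at which 2 of the 3 values shown sit.

As far as these compounds go, it remains open whether a small group such as methyl, or a chain ending in a carboxylic acid, on this nitrogen would keep the activity of compound 3. The compounds shown also leave open how the mirror image of compound 3 would compare with it.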